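The source may hold more compounds than are shown below. What is called first, only, known or untested is meant among the compounds shown, and "the series" means these compounds.

In an ADME assay on cells (Lymphocyte, Homo sapiens) for cytotoxicity, read by MTT assay, with a stated time of 48 h (on this read-out lower numbers stand for stronger inhibition and higher numbers for weaker inhibition), compound 1 (`COC(=O)/C(=C\c1ccc(OC(=O)c2ccccc2OC)cc1)Sc1ccnc2cc(Cl)ccc12`) gives > 100000 nM, which is a limit of the assay and not a number. Compound 2 (`COC(=O)/C(=C\c1ccc(OC(=O)c2cc(OC)cc(OC)c2)cc1)Sc1ccnc2cc(Cl)ccc12`) gives a true number, 84100 nM. Compound 3 (`COC(=O)/C(=C\c1ccc(OC(=O)c2c(OC)cccc2OC)cc1)Sc1ccnc2cc(Cl)ccc12`) gives > 100000 nM, again only a limit. Compound 4 (`COC(=O)/C(=C\c1ccc(OC(=O)c2cccc(OC)c2OC)cc1)Sc1ccnc2cc(Cl)ccc12`) has 2,3-dimethoxyphenyl in place of 2,6-dimethoxyphenyl on a carbonyl carbon. Two measured swaps of this same group bear on the change: an at least 1.1-fold lower number from compound 1 to compound 2 (0.07 log units; that floor lies within the scatter), and an at least 1.1-fold higher number from compound 2 to compound 3 (0.07 log units; that floor lies within the scatter). Neither shows a step beyond the scatter, and the series stays close to the limit of > 100000 nM in this assay, at which 2 of the 3 values shown sit. The expected change is therefore no more than scatter, an estimated at least 1.1-fold lower number from compound 3 to compound 4 (0.04 log units; that floor lies within the scatter). Compound 4 is expected at 90000 nM, with an estimated range of 50000 nM to 160000 nM.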

Compound 4, half-maximal inhibitory concentration: 86600 nM
For compound 4 the middle estimate is 1.0-fold (0.02 log units) above the measured one; the range from low to high includes it.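

The 2,3-dimethoxyphenyl group gives a true number where the 2,6-dimethoxyphenyl group gave only a limit, yet the change is only an at least 1.1-fold lower number from compound 3 to compound 4 (0.06 log units; that floor lies within the scatter). Against the 3,5-dimethoxyphenyl group the change is a 1.0-fold higher number from compound 2 to compound 4 (0.01 log units; within the scatter), and against the 2-methoxyphenyl group it is an at least 1.1-fold lower number from compound 1 to compound 4 (0.06 log units; that floor lies within the scatter). No step shows that the arrangement of methoxy groups on this phenyl matters, and the series stays at the edge of what can be read: the limit of > 100000 nM in this assay, at which 2 of the 4 values shown sit.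

From the compounds shown here alone, whether an amine or a carboxylic acid on this phenyl would move the number beyond the scatter stays open.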